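The source may report more compounds than this note shows. Statements on the series, on what has been measured and on what is new or still open speak of the compounds shown alone.

Going by the values given here, in a physicochemical assay for lipophilicity, at pH 7.4 (on this read-out higher numbers stand for higher lipophilicity and lower numbers for lower lipophilicity), compound 1 `Cc1cc(/C=C/C#N)cc(C)c1Oc1cc(Nc2ccc(C#N)cc2)c(N)cc1C(N)=O` gives 3.53 as the only true number. Compound 2 `CC(=O)CCc1cc(C)c(Oc2cc(Nc3ccc(C#N)cc3)c(N)cc2C(F)(F)F)c(C)c1` reads > 5 and this is a limit of the assay, not a number. Compound 3 `Cc1cc(C#N)cc(C)c1Oc1cc(Nc2ccc(C#N)cc2)c(N)cc1C(F)(F)F` reads > 5 and this too is a limit of the assay. The rest of the series thus stands at the limit of > 5 in this assay, at which 2 of the 3 values shown sit, and offers compound 1 no second number for comparison. Among the compounds with values here, the single measured step, a step that the two limits leave unreadable from compound 2 to compound 3, has no readable size and concerns a different place on the structure, so it gives no guide here.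

Compound 4 `CNC(=O)c1cc(N)c(Nc2ccc(C#N)cc2)cc1Oc1c(C)cc(/C=C/C#N)cc1C` differs from compound 1 in one place: methyl in place of hydrogen on an amide-type nitrogen, which is methyl in place of hydrogen on an amide-type nitrogen, or carbamoyl to methylcarbamoyl. Within the data shown here, no measured step covers this change. The expectation therefore starts from compound 1 at 3.53 and allows a small upward move in this assay close to the usual scatter. The estimated step is a number 0.27 log units higher from compound 1 to compound 4 (within the scatter). For compound 4 the estimated value is 3.8 with an expected range from 3.4 to 4.3.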

Compound 4, partition coefficient: 4.12
Estimate against measurement, compound 4: 0.32 log units below, and the stated range covers the measured number.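

In this assay, methyl in place of hydrogen on an amide-type nitrogen is a number 0.59 log units higher from compound 1 to compound 4 (beyond the scatter). Going by these compounds alone, this is the first change with a readable size, and the first evidence that this nitrogen responds to substitution on this read-out, as compound 4 gives a true number rather than a limit. Compound 2 and compound 3 remain limits of the assay, not numbers, so the step between them cannot be read and no second step can be set beside this one: the limit of > 5 in this assay, at which 2 of the 4 values shown sit.

On these data alone, a single methyl defines no trend, so it remains open whether an ethyl group or a longer chain on the same nitrogen would continue the move. An amine or a carboxylic acid carried on that nitrogen substituent would show whether the read-out can also move the other way.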